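Vero cytotoxicity notes: fluoro to nitro on pendant phenyl

The source may report more compounds than this note shows. Statements on the series, on what has been measured and on what is new or still open speak of the compounds shown alone.

Three compounds of the series have been run in an ADME assay on Vero cells (Chlorocebus sabaeus) for cytotoxicity, read by MTT assay, with a stated time of 72 h; a higher number here means that more compound is tolerated, a lower number that less compound is tolerated. Compound 1 `CC1=C(C(=O)Nc2ccc(Br)cn2)C(c2cn(-c3ccccc3)nc2-c2ccccc2)n2ncnc2N1` gives 25 ug/mL, compound 2 `CC1=C(C(=O)Nc2ccc(Br)cn2)C(c2cn(-c3ccccc3)nc2-c2ccc(F)cc2)n2ncnc2N1` gives 20 ug/mL, and compound 3 `CC1=C(C(=O)Nc2ccccn2)C(c2cn(-c3ccccc3)nc2-c2ccc(F)cc2)n2ncnc2N1` gives 20 ug/mL. Compound 2 stands level with compound 3 at the digits shown, the two together the lowest of the three numbers, and its gap to compound 1 is within the scatter, so no ordering among the three is supported.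

Compound 4 `CC1=C(C(=O)Nc2ccc(Br)cn2)C(c2cn(-c3ccccc3)nc2-c2ccc([N+](=O)[O-])cc2)n2ncnc2N1` is not yet measured. From compound 2 it differs by nitro in place of fluoro on an aromatic carbon.

Within the data shown here, two measured steps bear on this. On the same aromatic ring, a substitution gave a 1.3-fold lower number from compound 1 to compound 2 (0.10 log units; within the scatter). Elsewhere on the scaffold, a substitution gave no change at the digits printed from compound 2 to compound 3 (within the scatter). Among the measured compounds shown here, neither moves the number beyond the scatter, and no nitro-bearing compound has been measured, so there is no direct precedent for the group that enters. The expectation is therefore a step of no change at the digits printed from compound 2 to compound 4 (within the scatter), nothing beyond the scatter, with the range widened to allow for the untested group.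

Compound 4 is estimated at 20 ug/mL, with a range from 10 ug/mL to 40 ug/mL.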

Compound 4, half-maximal cytotoxic concentration: 25 ug/mL
Estimate against measurement, compound 4: 1.3-fold (0.10 log units) below; the range from low to high includes it.
By their numbers in this assay, from the lowest: compounds 2, 3, 1 and 4 (each within the scatter of the next).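

In this assay, the change from 4-fluorophenyl to 4-nitrophenyl, para to a large group, gives a 1.3-fold higher number from compound 2 to compound 4 (0.10 log units; within the scatter) and so extends the series to a group with more heavy atoms and with hydrogen-bond acceptors, which fluoro lacks. Measured against the unsubstituted phenyl, the same place gives no change at the digits printed from compound 1 to compound 4 (within the scatter), so hydrogen, fluoro and nitro, with the bromo group held constant, show no separation in this read-out. Nothing measured here gives a cause for this flat result.

Whether an amine, a carboxylic acid or a longer chain at this place would also stay within the scatter remains open, since the three groups shown cover only a narrow set of substituents. Also open, from the compounds shown here alone, is whether nitro would behave the same way with hydrogen in place of the bromo group, as in compound 3, because that exchange has so far been read only for the 4-fluorophenyl pair.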